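Swapping fluoro for difluoromethoxy in compound 2

The source may hold more compounds than are shown below. What is called first, only, known or untested is meant among the compounds shown, and "the series" means these compounds.

In an ADME assay on microsomes from liver (Homo sapiens) for metabolic stability, with a stated time of 10 min (on this read-out higher numbers stand for a more stable compound and lower numbers for a less stable compound), compound 1 (`FC(F)(F)c1ccccc1-c1ccc2[nH]c(C3=NC4(CCCCC4)CO3)nc2c1`) gives 85% and compound 2 (`Fc1ccccc1-c1ccc2[nH]c(C3=NOC4(CCCCC4)C3)nc2c1`) gives 79% on the same read-out. Compound 2 therefore stands within the scatter of compound 1, and these numbers do not separate the two. Both leave most of the compound in place over the stated time.

Compound 3 (`FC(F)Oc1ccccc1-c1ccc2[nH]c(C3=NOC4(CCCCC4)C3)nc2c1`) has not yet been measured. It keeps the core of compound 2 and changes one substituent, with difluoromethoxy in place of fluoro on an aromatic carbon, ortho to a large group (difluoromethoxy in place of fluoro on an aromatic carbon).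

Within the data shown here, no two measured compounds differ in only one place, so the data offer no direct guide to this swap. The expectation therefore stays close to the value of compound 2 (79%) and leans only slightly downward, without a move beyond the scatter. The expected change is a number 7 percentage points lower from compound 2 to compound 3 (within the scatter) on this estimate. Compound 3 is estimated at 72% with an expected range from 55% to 87% as its likely span.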

Compound 3, percent of the compound remaining: 100%
Compound 3: middle estimate off by 28 percentage points, on the low side, outside the stated range (above it).
By their numbers in this assay, from the lowest: compounds 2 and 1 (each within the scatter of the next); then compound 3.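

At this position, on an aromatic carbon ortho to a large group, the data now hold a step that can be read in one place: in this assay difluoromethoxy in place of fluoro gives a number 21 percentage points higher from compound 2 to compound 3 (beyond the scatter) and takes the read-out to its top, where compound 3 gives 100% and leaves no room to show anything higher. So this site tolerates the larger difluoromethoxy group without any loss on this read-out, and the change moves the number by more than the scatter, which the earlier comparison of two compounds differing in several places could not show. Nothing in the data on hand explains why this swap has this effect.

On these data alone, what remains open is whether the gain belongs to difluoromethoxy itself or would also appear with a plain methoxy group, a trifluoromethoxy group or a nitrile at the same place. As far as these compounds go, it is also open whether the same swap would act alike on the core of compound 1, since this is a single step on a single core and supports no wider pattern.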